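A few compounds are considered here, and "the series" means these few. Any claim that something is new, unique, unknown or untested is made for them only; others in the source may bear on it.

Of the compounds shown here, two share one core and have been measured in a functional assay on the whole organism (strain Swiss albino) with Mus musculus as the target, with stated times of 30 min and 10 min, at a dose of 50 mg/kg by the oral route; on this read-out higher numbers stand for more inhibition at the one dose given (going by the name of the read-out) and lower numbers for less inhibition. Compound 1 `Cc1cc2nn(-c3ccccc3)c(C)c2c(=O)o1` gives 50.2%, and compound 2 `Cc1cc2nn(-c3ccc(Cl)cc3)c(C)c2c(=O)o1` gives 65.3%, the higher of the two numbers shown. Among the compounds with values here, the single measured step, a number 15.1 percentage points higher from compound 1 to compound 2 (beyond the scatter), lies beyond the scatter of the method.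

Compound 3 `COc1ccc(-n2nc3cc(C)oc(=O)c3c2C)cc1` differs from compound 2 by methoxy in place of chloro on an aromatic carbon, on an aromatic carbon of a six-membered aromatic ring of carbon only, para to a large group. Within the data shown here, only the step from compound 1 to compound 2 bears on this change, and it concerns a different group at the same place, so the data do not tell in which direction a methoxy group will move the number. The step is expected to be small or within the scatter, with compound 3 estimated to fall at 55% in this assay, within 35% to 75%, a change of a number 10.3 percentage points lower from compound 2 to compound 3 (beyond the scatter) expected from compound 2.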

Compound 3, a percentage reported as inhibition, in the whole organism at one dose (the size of the read-out at that dose, not a potency): 75.9%
Estimate against measurement, compound 3: 20.9 percentage points below, and the stated range ends below it.
By their numbers in this assay, from the lowest: compound 1; then compound 2; then compound 3.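

At this place on the ring, para to a large group, a change from chloro to methoxy does not lower the number in this assay but gives a number 10.6 percentage points higher from compound 2 to compound 3 (beyond the scatter) and so moves it further up. Against hydrogen at the same place, methoxy gives a number 25.7 percentage points higher from compound 1 to compound 3 (beyond the scatter), so both groups measured here stand above hydrogen, and the position accepts two quite different substituents without a loss of inhibition at this dose. Nothing shown here offers a reason for this order.

Still open, on these data alone, is whether the number would climb further with an amine, a carboxylic acid or a longer chain such as ethoxy at this place. Also unknown is whether methoxy would give a similar step on another carbon of that ring.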